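The source may hold more compounds than are shown below. What is called first, only, known or untested is meant among the compounds shown, and "the series" means these compounds.

Working notes on the series.

The shared core is carried by compound 3 `Cc1cc(C)c(-c2c[nH]nc2C)cc1NC(=O)c1ccc(OCc2ccccn2)cc1`, which in an ADME assay on microsomes from liver (Rattus norvegicus) for metabolic stability (a higher number here means faster removal of the compound, a lower number slower removal), gives 55 mL.min-1.g-1. Within the three numbers measured so far this is the second highest: compound 1 `Cc1cc(C)c(-c2nc3ccccc3[nH]2)cc1NC(=O)c1ccc(OCc2ccccn2)cc1` gives 21 mL.min-1.g-1 in this assay, and compound 2 `Cc1csc(-c2cc(NC(=O)c3ccc(OCc4ccccn4)cc3)c(C)cc2C)n1` gives 147 mL.min-1.g-1. The steps among them are a 2.6-fold higher number from compound 1 to compound 3 (0.42 log units; beyond the scatter), a 7.0-fold higher number from compound 1 to compound 2 (0.85 log units; beyond the scatter) and a 2.7-fold lower number from compound 2 to compound 3 (0.43 log units; beyond the scatter).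

Compound 4 `Cc1cc(C)c(-c2c(C)nn(C)c2C)cc1NC(=O)c1ccc(OCc2ccccn2)cc1` has not yet been measured in this assay. It differs from compound 3 in one place: 1,3,5-trimethyl-1H-pyrazol-4-yl in place of 3-methyl-1H-pyrazol-4-yl on an aromatic carbon. Among the compounds with values here, none of the measured steps bears directly on this change; all three exchange one five-membered or fused ring system for another, whereas the step from compound 3 to compound 4 keeps the pyrazole and only adds methyl groups, removing the hydrogen-bond donor. The measured steps show that exchanges at this position move the number in this assay by modest amounts in either direction, so a step of similar or smaller size is expected here. Within the data shown here, with no closer precedent, compound 4 is expected to give 70 mL.min-1.g-1 in this assay, estimated within 30 mL.min-1.g-1 to 160 mL.min-1.g-1, which means an expected step of a 1.3-fold higher number from compound 3 to compound 4 (0.10 log units; within the scatter).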

Compound 4, intrinsic clearance in microsomes: 271 mL.min-1.g-1
For compound 4 the middle estimate is 3.9-fold (0.59 log units) below the measured one; the whole stated range lies below it.
By their numbers in this assay, from the lowest: compound 1; then compound 3; then compounds 2 and 4 (each within the scatter of the next).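

In this assay, a change that keeps the pyrazole ring and only adds methyl groups, taking the hydrogen-bond donors of the group from 1 to 0, still gives a 4.9-fold higher number from compound 3 to compound 4 (0.69 log units; beyond the scatter) and so lies beyond the scatter; this position therefore responds to the substitution on a retained ring and not only to the exchange of one ring system for another. Compound 4 joins compound 2 at the upper end of the series, with a 1.8-fold higher number from compound 2 to compound 4 (0.27 log units; within the scatter) lying within the scatter, while the span across the position widens to a 13-fold higher number from compound 1 to compound 4 (1.11 log units; beyond the scatter) and compound 1 remains the only one of the four with a number beyond the scatter of compound 3 on the lower side. Nothing at hand bears on why the number moves with this change.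

From the compounds shown here alone, the added methyl groups enter together in compound 4, and which of them carries the step remains open. Also open, going by these compounds, is how this assay would read with a hydroxymethyl group, a carboxylic acid or an amine on the pyrazole in place of one of those methyl groups.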